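Moving the fluorine: from compound 3 to compound 4

The compounds below may be only part of what the source reports. "The series", "measured", "known", "first", "only" and "open" are said of these compounds alone.

In an ADME assay on THP-1 cells (Homo sapiens) for cytotoxicity, read by flow cytometry and propidium iodide staining, with a stated time of 72 h (on this read-out higher numbers stand for weaker inhibition and lower numbers for stronger inhibition), compound 1 `CC(=O)Nc1ccc(O)c(C(=O)/C=C/c2ccc(F)cc2)c1` gives 68800 nM and compound 2 `CC(=O)Nc1ccc2oc(-c3ccccc3)cc(=O)c2c1` gives 97000 nM. Compound 3 `CC(=O)Nc1ccc2oc(-c3ccccc3F)cc(=O)c2c1` gives > 125000 nM, which is a limit and not a number. It sits at the limit of > 125000 nM in this assay, at which 1 of the 3 values shown sits.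

Compound 4 `CC(=O)Nc1ccc2oc(-c3ccc(F)cc3)cc(=O)c2c1` keeps the core of compound 3 and swaps a single group, next to the ring oxygen: 4-fluorophenyl in place of 2-fluorophenyl on an aromatic carbon. The atoms stay the same, and only the place of the fluorine differs.

Within the data shown here, the one measured step that bears on this is fluoro in place of hydrogen on an aromatic carbon, an at least 1.2-fold higher number from compound 2 to compound 3 (0.11 log units; that floor lies within the scatter). Among the measured compounds shown here, the size of that step stays within the scatter, and no measured step shows what moving the fluorine does. No step beyond the scatter is therefore expected in this assay, and the result may again be only a limit.

The estimated step is an at least 1.1-fold lower number from compound 3 to compound 4 (0.07 log units; that floor lies within the scatter). For compound 4 the expected value is 105000 nM, with an expected range from 65000 nM to 160000 nM.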

Compound 4, half-maximal inhibitory concentration: 22000 nM
Compound 4: the middle estimate sits 4.8-fold (0.68 log units) above what was measured; the measured number lies below the stated range.
By their numbers in this assay, from the lowest: compound 4; then compounds 1 and 2 (each within the scatter of the next). At a limit, above all of these: compound 3.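

In this assay, among these compounds, the place of the fluorine on the phenyl group makes a clear difference, which the earlier compounds could not show: 4-fluorophenyl in place of 2-fluorophenyl gives an at least 5.6-fold lower number from compound 3 to compound 4 (0.75 log units; beyond the scatter). Fluoro in place of hydrogen now also gives a step beyond the scatter when it enters as 4-fluorophenyl, a 4.4-fold lower number from compound 2 to compound 4 (0.64 log units; beyond the scatter), whereas the floor of the step to 2-fluorophenyl, an at least 1.2-fold higher number from compound 2 to compound 3 (0.11 log units; that floor lies within the scatter), lies within it. The value of compound 3 is a limit, so the step from it has only a floor and its full size stays unknown: the limit of > 125000 nM in this assay, at which 1 of the 4 values shown sits.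

Going by these compounds, whether this lower number is specific to fluorine stays open. A 4-chlorophenyl, 4-methoxyphenyl or 4-aminophenyl group in the same place would help to answer that.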